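Compound 4: carbonyl for sulfonyl on the amine nitrogen

This account rests on a few compounds, and the source may have more. Where it says the series, first, only, none or still open, it means among the compounds named here.

In an ADME assay on microsomes from liver (Homo sapiens) for metabolic stability, with a stated time of 10 min, tested at 0.5 uM (on this read-out higher numbers stand for a more stable compound and lower numbers for a less stable compound), compound 2 `C[C@@H](NS(=O)(=O)c1ccc(Cl)cc1)[C@H]1CC[C@@H](c2ccnc3ccc(F)cc32)CC1` gives 29% and compound 3 `C[C@@H](CNC(=O)c1ccc(Cl)cc1)[C@H]1CC[C@@H](c2ccnc3ccc(F)cc32)CC1` gives 56%, which leaves compound 2 the lower of the two numbers, with a gap beyond the scatter. Compound 1 `C[C@@H](C(=O)NC1CCCCC1)[C@H]1CC[C@@H](c2ccnc3ccc(F)cc32)CC1` reports only a limit of the assay, < 1%.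

Compound 4 `C[C@@H](NC(=O)c1cccc(Cl)c1)[C@H]1CC[C@@H](c2ccnc3ccc(F)cc32)CC1` carries (3-chlorophenyl)carbonyl in place of (4-chlorophenyl)sulfonyl on an amine nitrogen. Within the data shown here, no measured pair isolates this change. Compound 3, at 56%, also has a carbonyl on an amine nitrogen and points to a small rise in this assay, but compound 1 goes against it. The expected step of a number 6 percentage points higher from compound 2 to compound 4 (within the scatter) is upward and stays within the scatter. The estimate for compound 4 is 35%, with an expected range of 10% to 62%.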

Compound 4, percent of the compound remaining: 39%
Estimate against measurement, compound 4: 4 percentage points below; the range from low to high includes it.
By their numbers in this assay, from the lowest: compounds 2 and 4 (each within the scatter of the next); then compound 3. At a limit, below all of these: compound 1.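

In this assay, (3-chlorophenyl)carbonyl in place of (4-chlorophenyl)sulfonyl on an amine nitrogen gives the first step readable at this place, a number 10 percentage points higher from compound 2 to compound 4 (within the scatter). The two groups differ both in carbonyl against sulfonyl and in 3-chlorophenyl against 4-chlorophenyl, so this step reads both differences together. Nothing shown gives a cause for this step.

Open, from the compounds shown here alone, is how (4-chlorophenyl)carbonyl on the same nitrogen would stand, since it would separate the two differences. Also open, going by these compounds, is how a longer chain or a carboxylic acid at this place would read.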